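The source may report more compounds than this note shows. Statements on the series, on what has been measured and on what is new or still open speak of the compounds shown alone.

In an in vivo ADME assay on the whole organism (strain Sprague-Dawley) for pharmacokinetics, with Rattus norvegicus as the target (a lower number here means slower removal, a higher number faster removal of the compound), two compounds of this series have been measured so far. Compound 1 `NCc1ccccc1-c1ccc(C(=O)N2N=C(c3cccnc3)CC2c2ccccc2O)s1` gives 65 mL/min/kg in this assay. Compound 2 `NCc1ccccc1-c1ccc(C(=O)N2N=C(c3cccnc3)CC2c2c(O)cccc2F)s1` gives 26.7 mL/min/kg in this assay, which is the lower of the two numbers; the step of a 2.4-fold lower number from compound 1 to compound 2 (0.39 log units; beyond the scatter) separates them, and it is beyond the scatter. Compound 3 `O=C(c1ccc(-c2cccc3c2CCNC3)s1)N1N=C(c2cccnc2)CC1c1c(O)cccc1F` has not yet been measured in this assay. It differs from compound 2 by 1,2,3,4-tetrahydroisoquinolin-5-yl in place of 2-(aminomethyl)phenyl on an aromatic carbon. Among the measured compounds shown here, the only measured step, from compound 1 to compound 2, concerns a fluoro in place of hydrogen on an aromatic carbon and says nothing about the change that leads to compound 3; no measured pair shows a change of this kind, so nothing among the numbers points in either direction. The step expected in this assay, a 1.1-fold higher number from compound 2 to compound 3 (0.05 log units; within the scatter), is therefore not one beyond the scatter, and the doubt around it is wide. Compound 3 is thus estimated at 30 mL/min/kg in this assay, with a range from 12 mL/min/kg to 75 mL/min/kg.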

Compound 3, clearance: 11.7 mL/min/kg
Beside the measured number, compound 3's estimate is 2.6-fold (0.41 log units) above it, outside the stated range (below it).
By their numbers in this assay, from the lowest: compound 3; then compound 2; then compound 1.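

In this assay, among the compounds shown here, this is the first measured change at this place, on an aromatic carbon of a five-membered aromatic ring with 1 sulfur, next to the ring sulfur: 1,2,3,4-tetrahydroisoquinolin-5-yl in place of 2-(aminomethyl)phenyl gives a 2.3-fold lower number from compound 2 to compound 3 (0.36 log units; beyond the scatter). The number thus moves beyond the scatter although the entering group carries the same counts of nitrogen, hydrogen-bond donors and hydrogen-bond acceptors and no net charge; what differs in the counts is the added six-membered non-aromatic ring with 1 hetero atom and the rise from 8 to 10 heavy atoms. Nothing at hand gives a reason for the lower number, so the step stands as an observation only.

The compounds shown leave open whether the same change would lower the number to a similar extent without the fluoro on the phenol ring, since this step is seen on a single fluoro-bearing background. They also leave open how a tertiary amine, a hydroxyl or a carboxylic acid in place of the amine of the entering group would behave at this position.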